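The source may hold more compounds than are shown below. What is called first, only, known or untested is meant among the compounds shown, and "the series" means these compounds.

Measured so far in an assay on microsomes from intestine for inhibition of acyl-CoA:cholesterol acyltransferase (Oryctolagus cuniculus); a higher number here means a weaker inhibitor, a lower number a stronger inhibitor:

compound 1 `CCCCCCCCOC(=O)NC(=O)Oc1c(C(C)C)cccc1C(C)C` gives 250 nM
compound 2 `CC(C)c1cccc(C(C)C)c1OC(=O)NC(=O)SCc1ccc(Cl)cc1` gives 160 nM
compound 3 `CC(C)c1cccc(C(C)C)c1OC(=O)NC(=O)SCc1ccco1` gives 470 nM

All three share the same core and differ only in the group hanging from the second carbonyl. Compound 3 has the highest number of the three; its gap to compound 1 is within the scatter, while the step of a 2.9-fold higher number from compound 2 to compound 3 (0.47 log units; beyond the scatter) is beyond it, so compound 3 is a weaker inhibitor than compound 2 but cannot be ordered against compound 1.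

Compound 4 `CC(C)c1cccc(C(C)C)c1OC(=O)NC(=O)SCCCc1ccccc1` is the next step from compound 3: phenethyl in place of furan-2-yl on a saturated chain carbon bound to a sulfur. Within the data shown here, two measured steps bear on this. The step of a 2.9-fold higher number from compound 2 to compound 3 (0.47 log units; beyond the scatter) shows that a six-membered carbon-only ring in place of the furan ring lowers the number modestly. The step of a 1.9-fold higher number from compound 1 to compound 3 (0.27 log units; within the scatter) shows that a longer, more flexible chain at this position gave a number within the scatter of compound 3. Compound 4 combines both features, so a modest drop, a 2.1-fold lower number from compound 3 to compound 4 (0.33 log units; beyond the scatter), is expected in this assay. For compound 4 the expected value is 220 nM, with a likely range from 90 nM to 550 nM.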

Compound 4, half-maximal inhibitory concentration: 69 nM
Compound 4: middle estimate off by 3.2-fold (0.50 log units), on the high side; measured number below the stated range.
By their numbers in this assay, from the lowest: compound 4; then compounds 2, 1 and 3 (each within the scatter of the next, the first and the last beyond it).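

Lengthening the chain on the sulfur can matter more at this position than the earlier compounds suggested: the change to phenethyl gives a 6.8-fold lower number from compound 3 to compound 4 (0.83 log units; beyond the scatter), a larger step than any seen among compounds 1, 2 and 3. Compound 4 also improves on the chlorine-bearing compound 2, with a 2.3-fold lower number from compound 2 to compound 4 (0.37 log units; beyond the scatter), so a 4-chlorophenyl group on the shorter chain is not needed for a low number in this assay. No measurement shown explains either step.

Ring and chain length change together in both steps, so their separate contributions remain open; a 3-(furan-2-yl)propyl group or a plain benzyl group on the sulfur would help pull them apart. From the compounds shown here alone, whether a still longer chain, such as 4-phenylbutyl, lowers the number further also remains open.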